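The source may hold more compounds than are shown below. What is called first, only, known or untested is meant among the compounds shown, and "the series" means these compounds.

Measured so far in an ADME assay on TZM cells (Homo sapiens) for cytotoxicity, read by CCK-8 assay, with a stated time of 2 days; on this read-out higher numbers stand for lower toxicity in this test and lower numbers for higher toxicity in this test:

Compound 1, `COc1ccc(C(=O)Nc2ccc(CCS(=O)(=O)/C=C/c3ccc(OC(C)=O)c(OC(C)=O)c3)cc2)cc1`: 858000 nM
Compound 2, `CC(=O)Oc1ccc(/C=C/S(=O)(=O)CCc2ccc(NC(=O)c3ccc(F)cc3)cc2)cc1OC(C)=O`: 162000 nM
Compound 3, `CC(=O)Oc1ccc(/C=C/S(=O)(=O)CCc2ccc(NC(=O)c3cc(F)cc(F)c3)cc2)cc1OC(C)=O`: 225000 nM

Compound 3 stands second highest of the three numbers. Its nearest neighbour is compound 2: the step of a 1.4-fold higher number from compound 2 to compound 3 (0.14 log units; within the scatter) lies within the scatter, so the two cannot be told apart. Its furthest neighbour is compound 1: the step of a 3.8-fold lower number from compound 1 to compound 3 (0.58 log units; beyond the scatter) is modest and beyond the scatter. The remaining step, a 5.3-fold lower number from compound 1 to compound 2 (0.72 log units; beyond the scatter), is of the same modest size.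

The next compound, compound 4, is `CC(=O)Oc1ccc(/C=C/S(=O)(=O)CCc2ccc(NC(=O)C3CCCCC3)cc2)cc1OC(C)=O`. The change from compound 3 is cyclohexyl in place of 3,5-difluorophenyl on a carbonyl carbon. In plain terms, a six-membered aromatic ring of carbon only, with two fluorines, is exchanged for a six-membered non-aromatic ring of carbon only, on the carbonyl carbon next to the amide-type nitrogen.

Going by the values given here, none of the measured steps makes this exchange; all three only swap substituents on an aromatic ring that stays in place, and even so they move the number by at most a modest amount. The change to compound 4 is larger in kind, so a step beyond the scatter is possible, but the numbers give no direction for it. Compound 4 is therefore expected to land close to compound 3, with the step of a 1.1-fold higher number from compound 3 to compound 4 (0.05 log units; within the scatter) estimated to stay within the scatter, and its value estimated at 250000 nM, with a range from 100000 nM to 600000 nM.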

Compound 4, half-maximal cytotoxic concentration: 169000 nM
Estimate against measurement, compound 4: 1.5-fold (0.17 log units) above; the measured number falls inside the stated range.
By their numbers in this assay, from the lowest: compounds 2, 4 and 3 (each within the scatter of the next); then compound 1.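

In this assay, going by these compounds alone, the earlier steps only swapped substituents on an aromatic ring that stayed in place, whereas here the aromatic ring itself gives way to cyclohexyl on the carbonyl carbon, and the result cannot be told apart from either fluorinated partner: the steps are a 1.3-fold lower number from compound 3 to compound 4 (0.12 log units; within the scatter) and a 1.0-fold higher number from compound 2 to compound 4 (0.02 log units; within the scatter). Among these compounds, then, an aromatic ring at this position is not needed for the number to sit with those of compound 2 and compound 3, so losing the aromatic ring and both fluorines has no readable effect in this test. Compound 1, carrying 4-methoxyphenyl, remains apart by a modest margin, with a 5.1-fold lower number from compound 1 to compound 4 (0.71 log units; beyond the scatter), and no measurement here explains why the groups fall out this way.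

Every group shown on this carbonyl carbon is a six-membered ring of carbon only, so it remains open whether any such ring is needed at all. A straight alkyl chain or a piperidine ring carrying an amine nitrogen in this place would test how far the number holds once that ring type is gone.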